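Cyclohexyl for fluorophenyl on a weakly active amide arm

This account rests on a few compounds, and the source may have more. Where it says the series, first, only, none or still open, it means among the compounds named here.

Compound 1 `CCOC(=O)C1=Cc2ccccc2OC1(OCc1cn(CC(=O)Nc2ccccc2F)nn1)C(F)(F)F` is one of two measured compounds here. For the measured compounds named here, in a functional assay on A549 cells (Homo sapiens) for inhibition, read by MTT assay, with a stated time of 24 h (a higher number here means a weaker inhibitor, a lower number a stronger inhibitor), compound 1 gives 50100 nM, the only numerical value known so far. Compound 2 `O=C(O)C1=Cc2ccccc2OC1(OCc1cc(-c2ccc(F)cc2F)no1)C(F)(F)F` carries a different arm on the shared core. In this assay compound 2 reaches only > 150000 nM, which is a limit of the assay and not a number, in line with the limit of > 150000 nM in this assay, at which 1 of the 2 values shown sits.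

Compound 3 `CCOC(=O)C1=Cc2ccccc2OC1(OCc1cn(CC(=O)NC2CCCCC2)nn1)C(F)(F)F` has not yet been measured. It differs from compound 1 in a single place: cyclohexyl in place of 2-fluorophenyl on an amide-type nitrogen. Going by the values given here, no step between two measured compounds is known, so the size of this step can only be expected, not read off. A six-membered aromatic ring gives way to a six-membered non-aromatic ring on the amide-type nitrogen; with only weak activity on record, the writer expects a change of modest size in this assay, in no firm direction. Compound 3 is estimated at 60000 nM, between 20000 nM and 180000 nM. The expected step of a 1.2-fold higher number from compound 1 to compound 3 (0.08 log units; within the scatter) is small, within or near the scatter.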

Compound 3, half-maximal inhibitory concentration: 9900 nM
For compound 3 the middle estimate is 6.1-fold (0.78 log units) above the measured one; the measured number lies below the stated range.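

At the amide-type nitrogen, the ring matters: in this assay, cyclohexyl in place of 2-fluorophenyl gives a 5.1-fold lower number from compound 1 to compound 3 (0.70 log units; beyond the scatter), a step beyond the usual scatter and the first that can be read between two measured compounds here. With the rest of compound 1 held fixed, changing this arm alone moves the reading towards a stronger inhibitor, so a non-aromatic carbon ring is accepted at this place and reads better than the 2-fluorophenyl ring. Nothing shown here accounts for the size or direction of this step.

The compounds shown do not separate the loss of the aromatic ring from the loss of the fluorine, which a plain phenyl on this nitrogen would address. From the compounds shown here alone, how a cyclopentyl ring, a straight hexyl chain or a cyclohexyl ring bearing an amine would read in this assay also remains open.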